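Swapping the Carbamate Cap for a Ring-Bearing Group

This account rests on a few compounds, and the source may have more. Where it says the series, first, only, none or still open, it means among the compounds named here.

Of the compounds shown here, three have been measured in a functional assay on isolated protein for agonist activity at Glucose-dependent insulinotropic receptor (Homo sapiens), read by HTRF and cAMP accumulation; a lower number here means a smaller maximal response, a higher number a larger maximal response. Compound 1 `CC(C)(C)OC(=O)N1CCC(O[C@H]2CC[C@H](Oc3ccc(C#N)cc3)CC2)CC1` gives 116%, compound 2 `CC(C)S(=O)(=O)c1cnc(O[C@H]2CC[C@H](OC3CCN(C(=O)OC(C)(C)C)CC3)CC2)cn1` gives 109%, and compound 3 `CC(C)OC(=O)N1CCC(O[C@H]2CC[C@H](Oc3cnc(S(C)(=O)=O)cn3)CC2)CC1` gives 110%. Compound 3 stands second highest of the three numbers; its nearest neighbour is compound 2 and its furthest is compound 1, yet both gaps fall within the usual scatter, so the three compounds cannot be told apart on the largest response they reach. Compound 4 `CS(=O)(=O)c1cnc(O[C@H]2CC[C@H](OC3CCN(CC4(C(F)(F)F)CCCC4)CC3)CC2)cn1` has not yet been measured. It differs from compound 3 in one place: a group of 10 heavy atoms (7 carbon, 3 fluorine; one five-membered non-aromatic ring of carbon only) in place of a group of 6 heavy atoms (4 carbon, 2 oxygen; no ring), on an amine nitrogen in a ring The isopropoxycarbonyl leaves and a group with one five-membered non-aromatic ring of carbon only, carrying fluorine, enters on the amine nitrogen in the ring. Going by the values given here, no step between measured compounds touches this position, and the three known numbers sit close together. The expectation is that compound 4 stays near the others, with a step of a number 5 percentage points lower from compound 3 to compound 4 (within the scatter) that is not expected to go beyond the scatter. Compound 4 is estimated to reach 105%, in a range from 85% to 120%.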

Compound 4, largest response reached (Emax), in percent of the reference or control that the assay uses: 37%
Beside the measured number, compound 4's estimate is 68 percentage points above it; the whole stated range lies above it.
By their numbers in this assay, from the lowest: compound 4; then compounds 2, 3 and 1 (each within the scatter of the next).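

The amine nitrogen in the ring is not a free place to change. Compounds 1, 2 and 3 all carry a carbamate there and sit within the scatter of one another, so they gave no sign of how much this position matters, whereas replacing the isopropoxycarbonyl with the ring-bearing fluorinated group gives a number 73 percentage points lower from compound 3 to compound 4 (beyond the scatter) in this assay. Even so, compound 4 keeps a measurable response at 37%, and nothing here measures why the response fell.

The leaving carbonyl and the entering ring and fluorines changed in one step, so the data cannot separate their contributions. A plain cyclopentylmethyl group, lacking the trifluoromethyl, or an acetyl amide on the same nitrogen would help to separate them.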